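A few compounds are considered here, and "the series" means these few. Any claim that something is new, unique, unknown or untested is made for them only; others in the source may bear on it.

Compound 3 `C[C@@H](NC(=O)c1cccc(Cl)c1)[C@H]1CC[C@@H](c2ccnc3ccc(F)cc32)CC1` is one of three measured compounds that share a core and differ in the group carried on the side chain. In an assay on tissue (HeLa cells) for inhibition of Indoleamine 2,3-dioxygenase 1 (Homo sapiens), with stated times of 2 h and 18 h (on this read-out higher numbers stand for weaker inhibition and lower numbers for stronger inhibition), compound 3 gives 7 nM. Compound 1 `C[C@@H](CNc1ccc(Cl)cc1)[C@H]1CC[C@@H](c2ccnc3ccc(F)cc32)CC1` gives 7 nM, no change at the digits printed from compound 3, so the two lie within the scatter of each other and together hold the lowest numbers of the set. Compound 2 `C[C@@H](NCc1ccc(Cl)cc1)[C@H]1CC[C@@H](c2ccnc3ccc(F)cc32)CC1` gives 745 nM. The two measured steps are a 110-fold higher number from compound 1 to compound 2 (2.03 log units; beyond the scatter) and a 110-fold lower number from compound 2 to compound 3 (2.03 log units; beyond the scatter); both concern how the side chain is joined to the chlorinated ring, not the ring itself.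

Compound 4 `C[C@@H](NC(=O)C1CCCCC1)[C@H]1CC[C@@H](c2ccnc3ccc(F)cc32)CC1` has not yet been measured. It differs from compound 3 by cyclohexyl in place of 3-chlorophenyl on a carbonyl carbon. Neither measured step changes the ring on the carbonyl carbon, so neither bears directly on this change, and the measured compounds give no direct guide to its size. Compound 4 keeps the amide linkage that goes with the low number of compound 3 (7 nM), so a large step is not expected; a modest step toward a higher number is the expectation, a 4.3-fold higher number from compound 3 to compound 4 (0.63 log units; beyond the scatter). The estimate for compound 4 in this assay is 30 nM, with a range from 7 nM to 150 nM.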

Compound 4, half-maximal inhibitory concentration: 12 nM
Beside the measured number, compound 4's estimate is 2.5-fold (0.40 log units) above it; measured number inside the range.
By their numbers in this assay, from the lowest: compounds 1, 3 and 4 (each within the scatter of the next); then compound 2.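

In this assay, the change at the carbonyl carbon gives a 1.7-fold higher number from compound 3 to compound 4 (0.23 log units; within the scatter) and so shows that, between these two compounds, the 3-chlorophenyl group can give way to cyclohexyl, a non-aromatic ring of carbon only with no chlorine, without a change beyond the scatter. Compound 3 alone could not show this, as all three earlier compounds carry a chlorinated aromatic ring; now the large gap to the 4-chlorobenzyl amine also appears without that ring, with a 62-fold lower number from compound 2 to compound 4 (1.79 log units; beyond the scatter) as the step, while a 1.7-fold higher number from compound 1 to compound 4 (0.23 log units; within the scatter) keeps compound 4 within the scatter of the compound carrying the ((4-chlorophenyl)amino)methyl group. Nothing available here explains why the two rings on the carbonyl carbon read alike.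

The compounds shown leave open whether a ring containing nitrogen, such as piperidinyl, or an open chain, such as n-butyl, on the carbonyl carbon would also stay within the scatter of compound 3. They also leave open what an amine or a carboxylic acid on the cyclohexyl ring would do to the number.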